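The compounds below may be only part of what the source reports. "The series", "measured", "known", "first", "only" and "open" are said of these compounds alone.

Measured compounds:

compound 1, `CCCC#Cc1cn([C@@H]2O[C@H](CO)[C@@H](O)[C@H](O)[C@H]2O)c(=O)nc1N`. In a functional assay on L1210 cells (Mus musculus) for cytotoxicity, with a stated time of 48 h (a lower number here means a stronger inhibitor, a higher number a weaker inhibitor), compound 1 reaches only a limit of the assay, >= 250000 nM.
compound 2, `CCCCCc1ccc(C#Cc2cn([C@@H]3O[C@H](CO)[C@@H](O)[C@H](O)[C@H]3O)c(=O)nc2N)cc1`. Compound 2 gives 132000 nM.
compound 3, `CC(C)(C)c1ccc(C#Cc2cn([C@@H]3O[C@H](CO)[C@@H](O)[C@H](O)[C@H]3O)c(=O)nc2O)cc1`. Compound 3 gives 185000 nM.

Going by the values given here, compound 3 holds the higher of the two numbers so far; the nearest is compound 2, and the gap between them lies within the scatter, so no order between these two can be read. The value of compound 1 is not a number but a limit: the limit of >= 250000 nM in this assay, at which 1 of the 3 values shown sits.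

Compound 4, `CC(C)(C)c1ccc(C#Cc2cn([C@@H]3O[C@H](CO)[C@@H](O)[C@H](O)[C@H]3O)c(=O)nc2N)cc1`, differs from compound 3 in one place: amino in place of hydroxy on an aromatic carbon. Among the compounds with values here, no measured pair shows this exchange on an otherwise constant scaffold; compound 2, which carries the amino, and compound 3, which carries the hydroxy, differ also in the group on the phenyl ring. All numbers in this assay are weak and close to each other, so for the step from compound 3 to compound 4 a change no larger than the scatter is expected, a 1.2-fold lower number from compound 3 to compound 4 (0.09 log units; within the scatter). Compound 4 is estimated at 150000 nM, with a range from 60000 nM to 400000 nM.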

Compound 4, half-maximal inhibitory concentration: > 250000 nM
Compound 4 ended at the assay's limit; the forecaster's own chance of this, stated with the estimate: 25%; middle value at least 1.6-fold (0.22 log units) away from the limit.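

In this assay compound 4 reaches a limit of the assay and not a number: the limit of > 250000 nM in this assay, at which 1 of the 4 values shown sits.

Amino in place of hydroxy on an aromatic carbon gives an at least 1.3-fold higher number from compound 3 to compound 4 (0.13 log units; that floor lies within the scatter), the first reading of this exchange on an otherwise constant scaffold, and tert-butyl in place of pentyl on an aromatic carbon gives an at least 1.8-fold higher number from compound 2 to compound 4 (0.27 log units; that floor lies within the scatter). Both floors lie within the scatter, and neither step shows a lower number; the step between compound 1 and compound 4 cannot be read.

Open, as far as these compounds go, is how far past the limit compound 4 lies, so the true size of both steps remains unknown. Also open, from the compounds shown here alone, is whether methoxy or dimethylamino in place of the amino, or a carboxylic acid in place of the tert-butyl, would give a clearly lower number in this assay.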